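A few compounds are considered here, and "the series" means these few. Any claim that something is new, unique, unknown or untested is made for them only; others in the source may bear on it.

Measured so far: compound 1 `CC1=C(C(=O)OC(C)(C)C)C(c2ccsc2)NC(=O)N1` gives 15%; compound 2 `CC1=C(C(=O)OCc2ccccc2)C(c2ccsc2)NC(=O)N1` gives 57%; compound 3 `CC1=C(C(=O)OC(C)(C)C)C(c2ccco2)NC(=S)N1` gives 3%.

All three were tested in an assay on membranes from CHO cells for displacement of a labelled ligand from adenosine receptor A1 (Homo sapiens), read by scintillation counting, with a stated time of 60 min, tested at 1 uM; a higher number here means more inhibition at the concentration tested (going by the name of the read-out), a lower number less inhibition. For the measured compounds named here, the step of a number 42 percentage points higher from compound 1 to compound 2 (beyond the scatter) is the one change seen so far, and it is described as benzyl in place of tert-butyl on an oxygen next to a carbonyl group. Compound 3 differs from compound 1 in its core; the difference between the two cores is not broken down here. In this assay compound 3 gives 3%, the lowest of the three numbers, and compound 1 gives 15%.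

Compound 4 `CC1=C(C(=O)OCc2ccccc2)C(c2ccco2)NC(=S)N1` has not been measured. It differs from compound 3 by benzyl in place of tert-butyl on an oxygen next to a carbonyl group, the same change that separates compound 1 from compound 2, at the same place. Going by the values given here, the step from compound 3 to compound 4 is expected to be a number 32 percentage points higher from compound 3 to compound 4 (beyond the scatter), of similar size to the earlier one, because a number 42 percentage points higher from compound 1 to compound 2 (beyond the scatter) was large; the only caution is that compound 3 starts lower than compound 1 did, and one pair is a thin basis. Compound 4 is therefore estimated at 35% in this assay, within 10% to 60%.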

Compound 4, a percentage reported as inhibition, at one concentration (the size of the read-out at that concentration, not a potency): 32%
Compound 4: middle estimate off by 3 percentage points, on the high side, and the stated range covers the measured number.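

In this assay, benzyl in place of tert-butyl on an oxygen next to a carbonyl group gives a number 29 percentage points higher from compound 3 to compound 4 (beyond the scatter), so the change raises the number on the second core as well. For the compounds shown here, the two steps have the same direction, and the gap between their sizes is not beyond the scatter: the same change on two cores in this assay, a number 42 percentage points higher (beyond the scatter) from compound 1 to compound 2 and a number 29 percentage points higher (beyond the scatter) from compound 3 to compound 4, 13 percentage points apart, within the scatter of two such steps This shows that the change carried over between these two cores, but it rests on only two pairs, says nothing about any further core, and does not explain why the change raises the number.

Only tert-butyl and benzyl are shown on this oxygen, so it remains open whether a methyl, an ethyl, a longer chain or a benzyl with a chlorine on its ring would give a similar number. The compounds shown also do not separate the parts of the difference between the two cores, and readings at one concentration leave the potency of all four compounds open.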